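Piperazine cap swap on a quinoline core: toxicity outlook

The source may hold more compounds than are shown below. What is called first, only, known or untested is meant among the compounds shown, and "the series" means these compounds.

Compound 1, `NCCNc1cc(N2CCN(c3ccccc3)CC2)nc2ccccc12`, in an ADME assay on HEp-2 cells (Homo sapiens) for cytotoxicity, read by CCK-8 assay, with a stated time of 6 days (on this read-out lower numbers stand for higher toxicity in this test and higher numbers for lower toxicity in this test), gives 20800 nM.
Compound 2, `NCCNc1cc(N2CCN(C(=O)CCc3ccccc3)CC2)nc2ccccc12`, in this assay gives only a limit, > 100000 nM.
Compound 3, `NCCNc1cc(N2CCN(c3cccc(Cl)c3)CC2)nc2ccccc12`, in this assay gives 6400 nM.

Compound 3 shows the lowest number of the two numbers measured, with compound 1 nearest; the step of a 3.3-fold lower number from compound 1 to compound 3 (0.51 log units; beyond the scatter) lies beyond the scatter. Compound 4, `CS(=O)(=O)N1CCN(c2cc(NCCN)c3ccccc3n2)CC1`, is not yet measured. It differs from compound 3 in one place: methylsulfonyl in place of 3-chlorophenyl on an amine nitrogen in a ring. Among the measured compounds shown here, the steps that bear on this change are an at least 4.8-fold higher number from compound 1 to compound 2 (0.68 log units; beyond the scatter) and an at least 15-fold lower number from compound 2 to compound 3 (1.19 log units; beyond the scatter), both of which swap an aromatic cap on the ring nitrogen for a non-aromatic carbonyl group and both of which are cut off because of the limit of > 100000 nM in this assay, at which 1 of the 3 values shown sits. A methylsulfonyl cap, like the carbonyl cap of compound 2, is non-aromatic, so a large rise in this assay is expected, on the order of a 13-fold higher number from compound 3 to compound 4 (1.10 log units; beyond the scatter). Compound 4 is therefore expected to give about 80000 nM, within 25000 nM to 300000 nM, and may well return only a limit.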

Compound 4, half-maximal cytotoxic concentration: > 100000 nM
Compound 4: only a limit was reported; the forecaster's own chance of this, stated with the estimate: 50%; at least 1.2-fold (0.09 log units) between middle value and limit.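

In this assay, replacing the 3-chlorophenyl cap with methylsulfonyl gives an at least 15-fold higher number from compound 3 to compound 4 (1.19 log units; beyond the scatter), and replacing the phenyl cap of compound 1 gives an at least 4.8-fold higher number from compound 1 to compound 4 (0.68 log units; beyond the scatter); both steps rest on a limit. Until now, only compound 2 had reached that limit, and its phenethylcarbonyl cap still holds an aromatic ring, whereas the methylsulfonyl cap of compound 4 has no ring at all. Across these four compounds, the two caps with an aromatic ring set directly on the ring nitrogen give measured numbers, and the two others give limits, with no compound going against this.

On these data alone, the step from compound 2 to compound 4 cannot be read, so the two caps cannot be ranked: the limit of > 100000 nM in this assay, at which 2 of the 4 values shown sit. It remains open whether a smaller acetyl cap, or a free amine at this ring nitrogen, would also reach the limit.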